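This account rests on a few compounds, and the source may have more. Where it says the series, first, only, none or still open, it means among the compounds named here.

In a functional assay on RAW264.7 cells (Mus musculus) for inhibition, with stated times of 2 h and 24 h (a higher number here means a weaker inhibitor, a lower number a stronger inhibitor), compound 1 `COc1cc(OC)cc([C@@H]2C(=O)c3cc(OC)cc(OC)c3[C@H]2c2ccccc2)c1` gives a measured value of 27100 nM. Compound 2 `COc1cc(OC)cc([C@@H]2C(SCc3ccccc3)c3cc(OC)cc(OC)c3[C@H]2c2ccccc2)c1` gives only a limit, > 200000 nM. Compound 3 `COc1ccc([C@@H]2c3c(OC)cc(OC)cc3C(SCc3ccccc3)[C@H]2c2cc(OC)cc(OC)c2)cc1` also gives only a limit, > 200000 nM, so it has no exact place on the scale. That reading is the limit of > 200000 nM in this assay, at which 2 of the 3 values shown sit. The one measured step among these compounds is a step that the two limits leave unreadable from compound 2 to compound 3, so it offers no size to carry forward.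

Compound 4 `COc1ccc(C(O)C2c3cc(OC)cc(OC)c3[C@@H](c3ccc(OC)cc3)[C@@H]2c2cc(OC)cc(OC)c2)cc1` differs from compound 3 in one place: hydroxy(4-methoxyphenyl)methyl in place of benzylsulfanyl on a saturated ring carbon. The benzylsulfanyl group shared by compound 2 and compound 3 is therefore gone. Within the data shown here, compound 1, which also has no benzylsulfanyl group, gives the only readable number at 27100 nM. On that single comparison, a move toward stronger inhibition in this assay is expected, though a weak one, and another limit remains possible. The expected change is an at least 3.3-fold lower number from compound 3 to compound 4 (0.52 log units; beyond the scatter). For compound 4 the estimate is 60000 nM, with an expected range from 15000 nM to 200000 nM.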

Compound 4, half-maximal inhibitory concentration: > 200000 nM
Compound 4: no number, only a limit; the forecaster's own chance of this, stated with the estimate: 35%; middle value at least 3.3-fold (0.52 log units) from the limit.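

Compound 3 and compound 4 each give only a limit in this assay, so the step between them cannot be read: the limit of > 200000 nM in this assay, at which 3 of the 4 values shown sit. The compounds shown leave open whether putting hydroxy(4-methoxyphenyl)methyl in place of benzylsulfanyl changes inhibition at all.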